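The source may hold more compounds than are shown below. What is called first, only, known or untested is meant among the compounds shown, and "the series" means these compounds.

Measured compounds, with their results in a functional assay on PC-3 cells (Homo sapiens) for antiproliferative activity, read by MTT assay, with a stated time of 72 h; a higher number here means a weaker inhibitor, a lower number a stronger inhibitor:

compound 1, `CCOC(=O)c1csc2nc(CN3CCN(Cc4ccccc4)CC3)c(-c3ccc(OC)cc3)n12`, gives 29400 nM
compound 2, `CCOC(=O)c1csc2nc(CN3CCN(Cc4ccccc4)CC3)c(-c3ccc(Br)cc3)n12`, gives 56400 nM
compound 3, `COc1ccc(-c2cnc3scc(C(=O)NNC(C)=O)n23)cc1`, gives 28300 nM

Compound 1 and compound 2 share one core and differ by bromo in place of methoxy on an aromatic carbon. The step this makes in this assay is a 1.9-fold higher number from compound 1 to compound 2 (0.28 log units; within the scatter), so the two values cannot be told apart with confidence. Compound 3 carries a different core, and the difference between the two cores is not broken down here; its value in this assay sits close to that of compound 1 and within the scatter of compound 2 as well.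

Compound 4, `CC(=O)NNC(=O)c1csc2ncc(-c3ccc(Br)cc3)n12`, is not yet measured. Within the data shown here, it differs from compound 3 by bromo in place of methoxy on an aromatic carbon, which is the same change as the one from compound 1 to compound 2, made at the same place on the ring. Since that change gave only a 1.9-fold higher number from compound 1 to compound 2 (0.28 log units; within the scatter), the step from compound 3 to compound 4 is expected to be of similar size, a 1.7-fold higher number from compound 3 to compound 4 (0.23 log units; within the scatter), resting on that single earlier pair. Compound 4 is therefore estimated at 48000 nM in this assay, plausibly between 20000 nM and 115000 nM.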

Compound 4, half-maximal inhibitory concentration: 12700 nM
Compound 4: the middle estimate sits 3.8-fold (0.58 log units) above what was measured, outside the stated range (below it).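

In this assay, bromo in place of methoxy on an aromatic carbon gives a 2.2-fold lower number from compound 3 to compound 4 (0.35 log units; beyond the scatter), a modest step on the core of compound 3. Among these compounds, with only one pair on each core, this shows that neither the direction nor the size of the change can be assumed to carry over between these two cores, but it does not show what causes the difference or how the change would behave on any further core. Set side by side, the two steps differ, although only the second lies beyond the scatter on its own: the same change on two cores in this assay, a 1.9-fold higher number (0.28 log units; within the scatter) from compound 1 to compound 2 and a 2.2-fold lower number (0.35 log units; beyond the scatter) from compound 3 to compound 4, 4.3-fold (0.63 log units) apart, beyond the scatter of two such steps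

The compounds shown leave open which of the features separating the two cores governs the step, whether the ethyl ester, the benzylpiperazine arm or the acetyl hydrazide. They also leave open how a chloro, a trifluoromethyl or a dimethylamino group in place of methoxy would read on either core.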